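Swapping the aryl group on a sulfonamide nitrogen

A few compounds are considered here, and "the series" means these few. Any claim that something is new, unique, unknown or untested is made for them only; others in the source may bear on it.

Compound 1 `O=S(=O)(Nc1ccc(Cl)c(Cl)c1)c1ccc(-c2cnc(C3CC3)o2)cc1` gives 416 nM in a functional assay on cells (leukaemia cell line, Homo sapiens) for inhibition, read by sulforhodamine B assay, with a stated time of 48 h; on this read-out lower numbers stand for stronger inhibition of growth and higher numbers for weaker inhibition of growth.
Compound 2 `Cc1ccc(NS(=O)(=O)c2ccc(-c3cnc(C4CC4)o3)cc2)cc1C` gives 420 nM in this assay.
Compound 3 `O=S(=O)(Nc1ccc(F)cc1F)c1ccc(-c2cnc(C3CC3)o2)cc1` gives 356 nM in this assay.

Among the compounds with values here, compound 3 carries the lowest number of the three, but the gaps to its neighbours are small: a 1.2-fold lower number from compound 1 to compound 3 (0.07 log units; within the scatter) and a 1.2-fold lower number from compound 2 to compound 3 (0.07 log units; within the scatter), so no compound can be set apart from the others. Compound 4 `Cc1cc(F)cc(NS(=O)(=O)c2ccc(-c3cnc(C4CC4)o3)cc2)c1` differs from compound 3 in one place only: 3-fluoro-5-methylphenyl in place of 2,4-difluorophenyl on a sulfonamide nitrogen.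

All three measured steps change the same kind of group in the same place, and each stays within the scatter: a 1.0-fold higher number from compound 1 to compound 2 (0.00 log units; within the scatter), a 1.2-fold lower number from compound 1 to compound 3 (0.07 log units; within the scatter), a 1.2-fold lower number from compound 2 to compound 3 (0.07 log units; within the scatter). Three different aryl groups on the sulfonamide nitrogen thus gave numbers that cannot be told apart, and the change to compound 4 is of the same type. For compound 4 the expected step in this assay is therefore a 1.1-fold higher number from compound 3 to compound 4 (0.05 log units; within the scatter), that is, none beyond the scatter. Compound 4 is estimated at 400 nM, within 200 nM to 800 nM.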

Compound 4, concentration for 50% growth inhibition: 138 nM
For compound 4 the middle estimate is 2.9-fold (0.46 log units) above the measured one, outside the stated range (below it).
By their numbers in this assay, from the lowest: compound 4; then compounds 3, 1 and 2 (each within the scatter of the next).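

The aryl group on the sulfonamide nitrogen can matter after all: in this assay, 3-fluoro-5-methylphenyl gives a 2.6-fold lower number from compound 3 to compound 4 (0.41 log units; beyond the scatter), along with a 3.0-fold lower number from compound 2 to compound 4 (0.48 log units; beyond the scatter) and a 3.0-fold lower number from compound 1 to compound 4 (0.48 log units; beyond the scatter), so compound 4 is the most potent of the four, though each step is modest. The change itself is small, since the entering and leaving groups have the same heavy-atom count and both are a six-membered aromatic ring of carbon only. No supporting data bear on what lies behind this step.

The compounds shown do not separate the share of the fluorine from that of the methyl in 3-fluoro-5-methylphenyl. From the compounds shown here alone, it also remains open how this assay would respond to a methoxy group, an amine or a carboxylic acid on this aryl ring.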